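Dropping the pyridin-3-yl group: what compound 4 might show

A few compounds are considered here, and "the series" means these few. Any claim that something is new, unique, unknown or untested is made for them only; others in the source may bear on it.

In a functional assay on MGC-803 cells (Homo sapiens) for antiproliferative activity, read by CCK-8 assay, with a stated time of 72 h, tested at 8 uM (on this read-out higher numbers stand for a stronger effect at the one concentration tested and lower numbers for a weaker effect), three compounds have been measured:

compound 1 `Nc1ccccc1NC(=O)c1ccc(CSC(=S)N2CCN(Cc3ccccn3)CC2)cc1` gives 65.2%
compound 2 `Nc1ccccc1NC(=O)c1ccc(CSC(=S)N2CCCc3ccccc32)cc1` gives 87.5%
compound 3 `Nc1ccccc1NC(=O)c1ccc(CSC(=S)N2CCN(Cc3cccnc3)CC2)cc1` gives 64.6%

Compound 3 holds the lowest of the three numbers. Its nearest neighbour is compound 1: the step of a number 0.6 percentage points lower from compound 1 to compound 3 (within the scatter) is within the scatter, so the two cannot be told apart. Compound 2 stands furthest away, its number beyond the scatter above that of compound 3.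

Compound 4 `CN1CCN(C(=S)SCc2ccc(C(=O)Nc3ccccc3N)cc2)CC1` is not yet measured. It differs from compound 3 by hydrogen in place of pyridin-3-yl on a saturated chain carbon bound to an amine nitrogen in a ring. For the measured compounds named here, only one measured step touches the same place: a number 0.6 percentage points lower from compound 1 to compound 3 (within the scatter), which swaps one pyridinyl group for another and shows no effect beyond the scatter. Going by the values given here, no measured step removes the ring altogether and leaves a hydrogen, so the data give no direct guide for the size of this change. Among the compounds with values here, with the one nearby step flat, compound 4 is expected to land close to compound 3, with at most a modest lowering; the expected step is a number 6.6 percentage points lower from compound 3 to compound 4 (within the scatter). On that basis compound 4 is estimated to give 58% in this assay, in a range from 42% to 74%.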

Compound 4, a percentage reported as inhibition, at one concentration (the size of the read-out at that concentration, not a potency): 84.4%
The estimate for compound 4 lay 26.4 percentage points below the measured number; the whole stated range lies below it.
By their numbers in this assay, from the lowest: compounds 3 and 1 (each within the scatter of the next); then compounds 4 and 2 (each within the scatter of the next).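

In this assay, exchanging one pyridinyl group for the other had left the number unchanged within the scatter, but removing the ring altogether, so that methyl stands in place of (pyridin-3-yl)methyl, gives a number 19.8 percentage points higher from compound 3 to compound 4 (beyond the scatter). The matching change from the pyridin-2-yl series gives a number 19.2 percentage points higher from compound 1 to compound 4 (beyond the scatter), so at this position the presence of the ring matters in both cases, while the choice between the two pyridinyl groups does not show up. The step of a number 3.1 percentage points lower from compound 2 to compound 4 (within the scatter) also shows that, on the thiocarbonyl carbon, 4-methylpiperazin-1-yl and 1,2,3,4-tetrahydroquinolin-1-yl cannot be told apart here, and nothing available explains any of these differences.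

As far as these compounds go, it remains open whether an ethyl group, a 2-hydroxyethyl group or a bare amine hydrogen at this place would keep the number as high as the methyl group does, or whether a phenyl ring would bring it down as the pyridinyl groups do. With one cell line and a single concentration, these numbers also leave the potency of all the compounds undetermined.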